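Thiourea aryl swap on the shared core: pyridinyl for tolyl

The source may hold more compounds than are shown below. What is called first, only, known or untested is meant among the compounds shown, and "the series" means these compounds.

Of the compounds shown here, three on one shared core have been measured in a functional assay on MKN-74 cells (Homo sapiens) for antiproliferative activity, with a stated time of 24 h; on this read-out higher numbers stand for weaker inhibition and lower numbers for stronger inhibition. Compound 1 `NC(=O)c1c(NC(=O)c2ccccc2Cl)sc2c1CCN(Cc1ccc([N+](=O)[O-])cc1)C2` gives 31500 nM, compound 2 `NC(=O)c1c(NC(=O)c2ccccc2Cl)sc2c1CCN(C(=S)Nc1cccc3ccccc13)C2` gives 20700 nM, and compound 3 `Cc1ccccc1NC(=S)N1CCc2c(sc(NC(=O)c3ccccc3Cl)c2C(N)=O)C1` gives 11700 nM. Compound 3 thus carries the lowest of the three numbers, but its separation from compound 2 is only a 1.8-fold lower number from compound 2 to compound 3 (0.25 log units; within the scatter), which lies within the scatter, so no order between those two can be read; the step of a 2.7-fold lower number from compound 1 to compound 3 (0.43 log units; beyond the scatter) is modest and beyond the scatter.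

Compound 4 `NC(=O)c1c(NC(=O)c2ccccc2Cl)sc2c1CCN(C(=S)Nc1cccnc1)C2` is not yet measured. It differs from compound 3 by pyridin-3-yl in place of 2-methylphenyl on an amide-type nitrogen. The step that bears on this change is the earlier swap of aryl group on the same thiourea nitrogen, a 1.8-fold lower number from compound 2 to compound 3 (0.25 log units; within the scatter), which stayed within the scatter. The step from compound 1 concerns a different place and does not speak to it. A change of aryl on that nitrogen is therefore expected to move this assay by no more than the scatter, in no set direction.

Compound 4 is expected to give about 15000 nM, between 6000 nM and 40000 nM, an expected step of a 1.3-fold higher number from compound 3 to compound 4 (0.11 log units; within the scatter).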

Compound 4, half-maximal inhibitory concentration: 38600 nM
Beside the measured number, compound 4's estimate is 2.6-fold (0.41 log units) below it; the measured number falls inside the stated range.
By their numbers in this assay, from the lowest: compounds 3, 2, 1 and 4 (each within the scatter of the next, the first and the last beyond it).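

On the thiourea nitrogen, a change of aryl group now moves this assay beyond the scatter: pyridin-3-yl in place of 2-methylphenyl gives a 3.3-fold higher number from compound 3 to compound 4 (0.52 log units; beyond the scatter), a separation that the earlier swap of aryl groups on this nitrogen had not shown. Pyridin-3-yl in place of naphthalen-1-yl gives only a 1.9-fold higher number from compound 2 to compound 4 (0.27 log units; within the scatter), and the change on an amine nitrogen in a ring gives a 1.2-fold higher number from compound 1 to compound 4 (0.09 log units; within the scatter), so no order can be read between compound 4 and either of these two compounds. No measurement shown accounts for the step from 2-methylphenyl to pyridin-3-yl.

Going by these compounds, compound 4 changes both the methyl group and the ring atoms at once, and it remains open which of the two matters; a plain phenyl on the same nitrogen would separate them. Also open, on these data alone, is how an amine or a carboxylic acid on that aryl ring would read in this assay.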